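A Methyl Added to the Nitrophenyl Amide of Compound 3

The source may report more compounds than this note shows. Statements on the series, on what has been measured and on what is new or still open speak of the compounds shown alone.

Compound 1, `CCn1cc(C(=O)Nc2ccccc2)c(=O)c2cc(F)c(N3CCNC(C)C3)c(F)c21`: 12700 nM
Compound 2, `CCn1cc(C(=O)Nc2ccccc2N)c(=O)c2cc(F)c(N3CCNC(C)C3)c(F)c21`: 2700 nM
Compound 3, `CCn1cc(C(=O)Nc2cccc([N+](=O)[O-])c2)c(=O)c2cc(F)c(N3CCNC(C)C3)c(F)c21`: 2710 nM

All three numbers come from a functional assay on HCT-116 cells (Homo sapiens) for cytotoxicity, read by MTT assay; on this read-out higher numbers stand for weaker inhibition and lower numbers for stronger inhibition. Compound 3 holds the second highest of them: it lies within the scatter of compound 2 (a 1.0-fold higher number from compound 2 to compound 3 (0.00 log units; within the scatter)) and well apart from compound 1 (a 4.7-fold lower number from compound 1 to compound 3 (0.67 log units; beyond the scatter)). Compound 4, `CCn1cc(C(=O)Nc2ccc(C)c([N+](=O)[O-])c2)c(=O)c2cc(F)c(N3CCNC(C)C3)c(F)c21`, differs from compound 3 by methyl in place of hydrogen on an aromatic carbon. Going by the values given here, no measured step adds a methyl, so none bears on this change directly. The two steps that do exist, a 4.7-fold lower number from compound 1 to compound 2 (0.67 log units; beyond the scatter) and a 4.7-fold lower number from compound 1 to compound 3 (0.67 log units; beyond the scatter), each place a group on the phenyl ring and give modest lower numbers, while swapping between such groups changes nothing beyond the scatter. For compound 4 the expected step is therefore small, a 1.1-fold lower number from compound 3 to compound 4 (0.04 log units; within the scatter), with no clear direction, and the estimate is 2500 nM, in the range 1000 nM to 6500 nM.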

Compound 4, half-maximal inhibitory concentration: 11800 nM
For compound 4 the middle estimate is 4.7-fold (0.67 log units) below the measured one; the measured number lies above the stated range.
By their numbers in this assay, from the lowest: compounds 2 and 3 (each within the scatter of the next); then compounds 4 and 1 (each within the scatter of the next).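

In this assay, this ring carbon, ortho to a nitro group, proves sensitive to a single methyl (a 4.4-fold higher number from compound 3 to compound 4 (0.64 log units; beyond the scatter)), the only step shown in which adding a group to the phenyl ring raises the number. The same gap appears against the 2-aminophenyl amide (a 4.4-fold higher number from compound 2 to compound 4 (0.64 log units; beyond the scatter)). The lower number seen with the nitro group alone is lost, as the comparison with the plain phenyl amide shows (a 1.1-fold lower number from compound 1 to compound 4 (0.03 log units; within the scatter)). As far as these compounds go, whether a methyl here would do the same without the nitro group, or how an ethyl or a methoxy at this carbon would behave, stays open. Nothing available explains the shift.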